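Swapping methoxy for trifluoromethyl on the shared core

The source may report more compounds than this note shows. Statements on the series, on what has been measured and on what is new or still open speak of the compounds shown alone.

- compound 1 `COc1ccc(-c2nn(-c3ccccc3)cc2-c2nc3cc(F)ccc3[nH]2)cc1`: 1510 nM
- compound 2 `COc1ccc(-c2nn(-c3ccccc3)cc2-c2nc3cc(OC)ccc3[nH]2)cc1`: 3130 nM

In a functional assay on MCF7 cells (Homo sapiens) for antiproliferative activity, read by MTT assay, with a stated time of 48 h (on this read-out lower numbers stand for stronger inhibition and higher numbers for weaker inhibition), compound 2 has the higher of the two numbers, at 3130 nM. Compound 3 `COc1ccc(-c2nn(-c3ccccc3)cc2-c2nc3cc(C(F)(F)F)ccc3[nH]2)cc1` carries trifluoromethyl in place of methoxy on an aromatic carbon. Going by the values given here, only one measured step bears on this change: a 2.1-fold higher number from compound 1 to compound 2 (0.32 log units; beyond the scatter), a modest rise as methoxy replaced fluoro. Fluoro and trifluoromethyl are different groups, so this single step is only a loose guide. Removing methoxy is expected to give a similarly modest fall, and the expected change is a 1.6-fold lower number from compound 2 to compound 3 (0.22 log units; within the scatter). The estimate for compound 3 is 1900 nM, with an expected range of 750 nM to 4800 nM.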

Compound 3, half-maximal inhibitory concentration: 5730 nM
Compound 3: the middle estimate sits 3.0-fold (0.48 log units) below what was measured; the whole stated range lies below it.
By their numbers in this assay, from the lowest: compound 1; then compounds 2 and 3 (each within the scatter of the next).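

In this assay the change from methoxy to trifluoromethyl gives a 1.8-fold higher number from compound 2 to compound 3 (0.26 log units; within the scatter) and so does not separate these two groups at this aromatic carbon. Going from fluoro to trifluoromethyl gives a 3.8-fold higher number from compound 1 to compound 3 (0.58 log units; beyond the scatter) and leaves compound 1 with the lowest number of the three, clear of both other groups. No measurement at hand explains this difference. Going by these compounds, whether an amine or a carboxylic acid on this same carbon would give a number lower than that of compound 1 remains open.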